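The compounds below may be only part of what the source reports. "The series", "measured", "known", "first", "only" and "open" are said of these compounds alone.

Measured so far in an ADME assay on Vero cells (Chlorocebus sabaeus) for cytotoxicity, read by MTT assay, with a stated time of 2 days; a higher number here means a weaker inhibitor, a lower number a stronger inhibitor:
- compound 1 `Cc1ccc(C(=O)Nc2cc3nc(C4CCCCC4)[nH]c3cc2Oc2ccc(F)cc2)cc1` gives 26000 nM
- compound 2 `Cc1ccc(C(=O)Nc2cc3nc(C4CCCCC4)[nH]c3cc2Sc2ccccc2)cc1` gives 6250 nM
- compound 3 `CCCCSc1cc2[nH]c(C3CCCCC3)nc2cc1NC(=O)c1ccc(C)cc1` gives only a limit of the assay, > 200000 nM

Compound 1 holds the highest of the two numbers recorded; compound 2 sits lower, by a 4.2-fold lower number from compound 1 to compound 2 (0.62 log units; beyond the scatter). The limit for compound 3 is the limit of > 200000 nM in this assay, at which 1 of the 3 values shown sits.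

The step to compound 4 `CCCCOC(=O)Nc1cc2nc(C3CCCCC3)[nH]c2cc1Oc1ccc(F)cc1` is butoxy in place of 4-methylphenyl on a carbonyl carbon. Among the compounds with values here, none of the measured steps touches this carbonyl carbon: a 4.2-fold lower number from compound 1 to compound 2 (0.62 log units; beyond the scatter), an at least 7.6-fold higher number from compound 1 to compound 3 (0.88 log units; beyond the scatter) and an at least 32-fold higher number from compound 2 to compound 3 (1.50 log units; beyond the scatter) all alter the group on the aromatic carbon or on the sulfur, and the amide side remains unchanged throughout. Within the data shown here, no direct precedent exists for the change, so no step beyond the scatter is expected in this assay. Compound 4 is therefore expected at 30000 nM, within 10000 nM to 100000 nM. The expected step is a 1.2-fold higher number from compound 1 to compound 4 (0.06 log units; within the scatter).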

Compound 4, half-maximal inhibitory concentration: 60000 nM
For compound 4 the middle estimate is 2.0-fold (0.30 log units) below the measured one; the measured number falls inside the stated range.
By their numbers in this assay, from the lowest: compound 2; then compound 1; then compound 4. At a limit, above all of these: compound 3.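

In this assay, the carbonyl carbon also proves sensitive to change: butoxy in place of 4-methylphenyl gives a 2.3-fold higher number from compound 1 to compound 4 (0.36 log units; beyond the scatter). The earlier steps shown here altered only the group on the aromatic carbon or on the sulfur, leaving the amide side unread. Nothing measured here accounts for this step.

On these data alone, whether the step follows from the loss of the aromatic ring or from the entering oxygen stays open. A pentyl or a benzyloxy group on this carbonyl carbon would separate the two.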